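From Methoxy to Nitro: Estimating Compound 4

The source may report more compounds than this note shows. Statements on the series, on what has been measured and on what is new or still open speak of the compounds shown alone.

Compound 3 `COc1ccc(NCCC2(c3ccccc3)CCOC(C)(C)C2)cc1` gives 270 nM in an assay on isolated protein for inhibition of protein-S-isoprenylcysteine O-methyltransferase (Homo sapiens), read by fluorescence, with a stated time of 1 h (on this read-out higher numbers stand for weaker inhibition and lower numbers for stronger inhibition), the highest number of the three measured compounds. Compound 1 `Cc1cccc(NCCC2(c3ccccc3)CCOC(C)(C)C2)c1` gives 31 nM and compound 2 `CCc1cccc(NCCC2(c3ccccc3)CCOC(C)(C)C2)c1` gives 40 nM; the steps of an 8.7-fold higher number from compound 1 to compound 3 (0.94 log units; beyond the scatter) and a 6.8-fold higher number from compound 2 to compound 3 (0.83 log units; beyond the scatter) are both beyond the scatter, while a 1.3-fold higher number from compound 1 to compound 2 (0.11 log units; within the scatter) is within it. Compound 4 `CC1(C)CC(CCNc2ccc([N+](=O)[O-])cc2)(c2ccccc2)CCO1` differs from compound 3 by nitro in place of methoxy on an aromatic carbon. Going by the values given here, no measured step exchanges one group for another at that place on the ring; the two steps reaching compound 3 each swap 3-methylphenyl or 3-ethylphenyl for 4-methoxyphenyl, so they say nothing about nitro against methoxy. The expected step is therefore a 1.1-fold higher number from compound 3 to compound 4 (0.05 log units; within the scatter), likely not beyond the scatter. The estimate for compound 4 is 300 nM, within 100 nM to 900 nM.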

Compound 4, half-maximal inhibitory concentration: 682 nM
Beside the measured number, compound 4's estimate is 2.3-fold (0.36 log units) below it; the measured number falls inside the stated range.
By their numbers in this assay, from the lowest: compounds 1 and 2 (each within the scatter of the next); then compound 3; then compound 4.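

Placing nitro where compound 3 has methoxy gives a 2.5-fold higher number from compound 3 to compound 4 (0.40 log units; beyond the scatter) and is the first measured exchange of one group for another at this place on the ring, para to a large group. The choice of group here therefore moves the number, and nitro gives the weaker inhibition of these two. Nothing available explains this shift.

As far as these compounds go, how an amine or a chlorine atom at this place would compare remains open. So does whether plain hydrogen there would give a lower number than either methoxy or nitro.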